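The source may hold more compounds than are shown below. What is called first, only, known or untested is meant among the compounds shown, and "the series" means these compounds.

In an ADME assay on WI-38 cells (Homo sapiens) for cytotoxicity, read by MTT assay, with a stated time of 72 h (on this read-out higher numbers stand for weaker inhibition and lower numbers for stronger inhibition), compound 2 `CCN(CC)CCn1cnnc1-c1cc(Oc2ccc(NC(=O)Nc3ccc(Cl)c(C(F)(F)F)c3)cc2F)ccn1` gives 6730 nM. Compound 1 `CN(C)CCn1cnnc1-c1cc(Oc2ccc(NC(=O)Nc3ccc(Cl)c(C(F)(F)F)c3)cc2F)ccn1` gives 3760 nM, and compound 3 `CCN(CC)CCn1cnnc1-c1cc(Oc2ccc(NC(=O)Nc3ccc(Cl)cc3Cl)cc2F)ccn1` gives 4280 nM; the steps of a 1.8-fold higher number from compound 1 to compound 2 (0.25 log units; within the scatter) and a 1.6-fold lower number from compound 2 to compound 3 (0.20 log units; within the scatter) both lie within the scatter, so compound 2 is not separated from either neighbour. Compound 4 `CN(C)CCCn1cnnc1-c1cc(Oc2ccc(NC(=O)Nc3ccc(Cl)c(C(F)(F)F)c3)cc2F)ccn1` differs from compound 2 by (dimethylamino)methyl in place of diethylamino on a saturated chain carbon, two bonds along the chain from an aromatic nitrogen. Among the compounds with values here, the one measured step that touches the same place, a 1.8-fold higher number from compound 1 to compound 2 (0.25 log units; within the scatter), swapped the alkyl groups on that amine and stayed within the scatter, so a change of chain length and alkyl groups at this position is expected to move this assay by nothing beyond the scatter. The expected step is a 1.3-fold lower number from compound 2 to compound 4 (0.13 log units; within the scatter). Compound 4 is estimated at 5000 nM, in a range from 2500 nM to 10000 nM.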

Compound 4, half-maximal inhibitory concentration: 7910 nM
The estimate for compound 4 lay 1.6-fold (0.20 log units) below the measured number; low and high end bracket the measured number.
By their numbers in this assay, from the lowest: compounds 1, 3, 2 and 4 (each within the scatter of the next, the first and the last beyond it).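

In this assay the change from 2-(diethylamino)ethyl to 3-(dimethylamino)propyl gives a 1.2-fold higher number from compound 2 to compound 4 (0.07 log units; within the scatter) and so does not separate these two compounds. Within the data shown here, with the dimethylamino end kept, the change from 2-(dimethylamino)ethyl to 3-(dimethylamino)propyl gives a 2.1-fold higher number from compound 1 to compound 4 (0.32 log units; beyond the scatter), the first step at this position to pass the scatter, though only modestly. Nothing available accounts for this step. Open questions remain for a longer chain, such as 4-(dimethylamino)butyl, and for a ring amine, such as morpholine, at the chain end.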